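Chlorine moved on the benzyl group of compound 2

The source may hold more compounds than are shown below. What is called first, only, known or untested is meant among the compounds shown, and "the series" means these compounds.

Among the compounds with values here, compound 2 `Nc1nc(Cc2cccc(Cl)c2)nc2cn(-c3ccccc3)nc12` gives 32% in an assay on CHO cells for displacement of a labelled ligand from adenosine receptor A1 (Homo sapiens), read by scintillation counting, tested at 1 uM (a lower number here means less inhibition, a higher number more inhibition at the concentration tested (going by the name of the read-out)), the higher of the two numbers so far; compound 1 `CC(C)c1nc(N)c2nn(-c3ccccc3)cc2n1` gives 2%. Within the data shown here, the single measured step, a number 30 percentage points higher from compound 1 to compound 2 (beyond the scatter), concerns the group on the core and not the position of the chlorine. Compound 3 `Nc1nc(Cc2ccc(Cl)cc2)nc2cn(-c3ccccc3)nc12` carries the change (4-chlorophenyl in place of 3-chlorophenyl on a saturated chain carbon bound to an aromatic carbon). Among the measured compounds shown here, no measured step bears on this change, so no step beyond the scatter is expected: for compound 3 the estimate is 30%, within 10% to 55%, with an expected step of a number 2 percentage points lower from compound 2 to compound 3 (within the scatter).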

Compound 3, a percentage reported as inhibition, at one concentration (the size of the read-out at that concentration, not a potency): 49%
Estimate against measurement, compound 3: 19 percentage points below, within the range that was stated.
By their numbers in this assay, from the lowest: compound 1; then compound 2; then compound 3.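

Moving the chlorine on the benzyl group counts in this assay, with a number 17 percentage points higher from compound 2 to compound 3 (beyond the scatter) for the same atoms joined differently. Compounds 1 and 2 showed only that 3-chlorobenzyl reads higher than isopropyl on the core, while 4-chlorobenzyl extends that gain, with a number 47 percentage points higher from compound 1 to compound 3 (beyond the scatter) for that exchange. Nothing measured here accounts for the difference between the two chlorine positions.

Still open, as far as these compounds go, is how 2-chlorobenzyl or unsubstituted benzyl would compare. Also open, from the compounds shown here alone, is whether 4-methoxybenzyl or a longer chain such as 2-(4-chlorophenyl)ethyl would hold the gain.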